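Thiophen-2-yl in Place of 2-Phenylethenyl: Expected Cytotoxicity

A few compounds are considered here, and "the series" means these few. Any claim that something is new, unique, unknown or untested is made for them only; others in the source may bear on it.

Compound 1, `COc1ccc2c(c1)c(/C=C1/C(=O)Nc3ccc(F)cc31)cn2Cc1cn([C@@H]2O[C@H](COC(C)=O)[C@@H](OC(C)=O)[C@H](OC(C)=O)[C@H]2OC(C)=O)nn1`, in a functional assay on MCF7 cells (Homo sapiens) for cytotoxicity, read by sulforhodamine B assay, with a stated time of 48 h (a higher number here means a weaker inhibitor, a lower number a stronger inhibitor), gives a limit of > 200000 nM.
Compound 2, `CC(=O)OC[C@H]1O[C@@H](n2cc(CN3C(=O)/C(=C\C=C\c4ccccc4)c4ccccc43)nn2)[C@H](OC(C)=O)[C@@H](OC(C)=O)[C@@H]1OC(C)=O`, in this assay gives 34100 nM.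
Compound 3, `CC(=O)OC[C@H]1O[C@@H](n2cc(CN3C(=O)/C(=C/C=C/c4ccccc4)c4ccccc43)nn2)[C@H](OC(C)=O)[C@@H](OC(C)=O)[C@@H]1OC(C)=O`, in this assay gives 53200 nM.

Compound 3 has the highest of the two numbers shown; its nearest neighbour is compound 2, with a 1.6-fold higher number from compound 2 to compound 3 (0.19 log units; within the scatter), a step that rests only on (the fact that compounds 2 and 3 differ only in the configuration as drawn). Compound 4, `CC(=O)OC[C@H]1O[C@@H](n2cc(CN3C(=O)/C(=C/c4cccs4)c4ccccc43)nn2)[C@H](OC(C)=O)[C@@H](OC(C)=O)[C@@H]1OC(C)=O`, differs from compound 3 by thiophen-2-yl in place of 2-phenylethenyl on a double-bonded chain carbon bound to a double-bonded ring carbon. No measured step touches this kind of change; the one step shown, between compound 2 and compound 3, concerns drawn configuration alone and lies within the scatter. Compound 4 is therefore expected to sit close to compound 3, with a 1.1-fold lower number from compound 3 to compound 4 (0.03 log units; within the scatter) as the estimated step, and the value for compound 4 is estimated at 50000 nM, between 15000 nM and 200000 nM.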

Compound 4, half-maximal inhibitory concentration: 28100 nM
Beside the measured number, compound 4's estimate is 1.8-fold (0.25 log units) above it; low and high end bracket the measured number.
By their numbers in this assay, from the lowest: compounds 4, 2 and 3 (each within the scatter of the next). At a limit, above all of these: compound 1.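

In this assay, the place on a double-bonded chain carbon bound to a double-bonded ring carbon now shows its first change of group, thiophen-2-yl in place of 2-phenylethenyl: a 1.9-fold lower number from compound 3 to compound 4 (0.28 log units; within the scatter). The earlier step concerned drawn configuration alone, whereas this one shows that a five-membered aromatic ring with sulfur can replace the 2-phenylethenyl group without a step beyond the scatter. Nothing given here accounts for this step. Still open, as far as these compounds go, is whether an amine or a carboxylic acid at this place would give a step beyond the scatter.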